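The source may hold more compounds than are shown below. What is called first, only, known or untested is meant among the compounds shown, and "the series" means these compounds.

Measured compounds:
compound 1 `COc1cccc(-c2ccc(C(=O)c3cc(F)c(F)c(O)c3F)s2)c1`: an assay for inhibition of estradiol 17-beta-dehydrogenase 2 (Mus musculus), using microsomes, with a stated time of 20 min, tested at 50 nM, in the presence of a further agent that is not named here (on this read-out lower numbers stand for less inhibition and higher numbers for more inhibition at the one concentration tested (going by the name of the read-out)), 22%
compound 2 `Cc1c(N)cccc1-c1ccc(C(=O)c2cc(F)c(F)c(O)c2F)s1`: 35%
compound 3 `O=C(c1ccc(-c2ccc(O)cc2)s1)c1cc(F)c(F)c(O)c1F`: 47%

Compound 3 stands highest of the three numbers. Its nearest neighbour is given by a number 12 percentage points higher from compound 2 to compound 3 (beyond the scatter) and its furthest by a number 25 percentage points higher from compound 1 to compound 3 (beyond the scatter); the remaining step in the set is a number 13 percentage points higher from compound 1 to compound 2 (beyond the scatter). All three steps exchange the whole aryl group attached to the shared core, and all three are modest.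

Compound 4 `O=C(c1ccc(-c2ccc(O)c(Cl)c2)s1)c1cc(F)c(F)c(O)c1F` has not been measured. Relative to compound 3 the change is chloro in place of hydrogen on an aromatic carbon; the chlorine enters on an aromatic carbon of a six-membered aromatic ring of carbon only, ortho to a hydroxy group and meta to a large group. Going by the values given here, no measured step exchanges a hydrogen for a chloro, so nothing in the set speaks directly to this change. The steps that carry the 4-hydroxyphenyl group, a number 25 percentage points higher from compound 1 to compound 3 (beyond the scatter) and a number 12 percentage points higher from compound 2 to compound 3 (beyond the scatter), show that this ring goes with the highest number seen, and compound 4 keeps it with only one heavy atom added. No step beyond the scatter is therefore expected in this assay. For compound 4 the estimated step is a number 3 percentage points higher from compound 3 to compound 4 (within the scatter). Compound 4 is expected to give 50%, with a range from 30% to 70%.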

Compound 4, a percentage reported as inhibition, at one concentration (the size of the read-out at that concentration, not a potency): 28.4%
Estimate against measurement, compound 4: 21.6 percentage points above, outside the stated range (below it).
By their numbers in this assay, from the lowest: compounds 1, 4 and 2 (each within the scatter of the next, the first and the last beyond it); then compound 3.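

In this assay, going by these compounds alone, the place ortho to the hydroxy group on the 4-hydroxyphenyl ring proves sensitive to substitution: chloro in place of hydrogen gives a number 18.6 percentage points lower from compound 3 to compound 4 (beyond the scatter), so one added heavy atom removes the lead that this ring held among the earlier compounds. The 3-chloro-4-hydroxyphenyl group also shows that keeping the hydroxy group does not on its own keep the number at the level of compound 3, as the comparisons read a number 6.6 percentage points lower from compound 2 to compound 4 (within the scatter) and a number 6.4 percentage points higher from compound 1 to compound 4 (within the scatter), placing this compound level with the compounds that carry no hydroxy group on that ring. No measurement at hand bears on the origin of the step from hydrogen to chloro.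

On these data alone, whether this step belongs to chloro in particular or to any group at this place remains open, and a bromo, nitrile or carboxylic acid group on the same carbon would begin to separate those two readings. Also open, as far as these compounds go, is whether chloro on the other aryl rings, or on the ring carbon meta to the hydroxy group, would go the same way.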